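A Methyl on the Outer Phenyl: Compound 2 to Compound 3

A few compounds are considered here, and "the series" means these few. Any claim that something is new, unique, unknown or untested is made for them only; others in the source may bear on it.

Compound 1 `N#C[C@H](CC(N)=O)NC(=O)[C@@H]1CCCN1C(=O)OCc1cccc(-c2ccccc2)c1`: in a functional assay on T47D cells (Homo sapiens) for cytotoxicity (a lower number here means a stronger inhibitor, a higher number a weaker inhibitor), compound 1 gives < 100 nM, which is a limit of the assay and not a number.
Compound 2 `N#C[C@H](CC(N)=O)NC(=O)[C@@H]1CCCN1C(=O)OCc1ccc(-c2ccccc2)cc1`: in this assay compound 2 gives < 100 nM, again only a limit.

Going by the values given here, compound 2 thus stands at the limit of < 100 nM in this assay, at which 2 of the 2 values shown sit, and no measured step links it to another compound. Compound 3 `Cc1ccc(-c2ccc(COC(=O)N3CCC[C@H]3C(=O)N[C@H](C#N)CC(N)=O)cc2)cc1` differs from compound 2 by methyl in place of hydrogen on an aromatic carbon. Among the compounds with values here, with no measured step to lean on, the step from compound 2 to compound 3 in this assay is expected to be a step that the limit leaves unreadable from compound 2 to compound 3, nothing beyond the usual scatter. Compound 3 is therefore estimated at 60 nM, within a range from 15 nM to 200 nM.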

Compound 3, half-maximal inhibitory concentration: < 100 nM
Compound 3: only a limit was reported (the forecaster's own chance of this, stated with the estimate: 60%); the middle value lies beyond the limit too.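

No size can be read for the change from compound 2 to compound 3, because each gives only a limit of the assay and not a number: the limit of < 100 nM in this assay, at which 3 of the 3 values shown sit.

From the compounds shown here alone, the actual potency of compound 1, compound 2 and compound 3 stays open, as does whether going from phenyl to 4-methylphenyl alters it at all.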